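The source may report more compounds than this note shows. Statements on the series, on what has been measured and on what is new or still open speak of the compounds shown alone.

Measured compounds in this series:

- compound 1, `O=C(NCc1ccccc1)c1cnc2nc(Cl)ccc2c1O`; in an assay for binding affinity to adenosine receptor A1 (Bos taurus) (on this read-out higher numbers stand for weaker inhibition and lower numbers for stronger inhibition), compound 1 gives 586 nM
- compound 2, `O=C(NCc1ccccc1)c1cnc2nc(NCc3ccccc3)ccc2c1O`; in this assay compound 2 gives 677 nM

On the numbers shown, compound 2 stands beside compound 1 and nowhere else: the step of a 1.2-fold higher number from compound 1 to compound 2 (0.06 log units; within the scatter) is within the scatter, so the two compounds are not separated by the measurement, and compound 2 cannot be placed above or below compound 1.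

Compound 3, `CN(C)c1ccc2c(O)c(C(=O)NCc3ccccc3)cnc2n1`, has not been measured. It differs from compound 2 by dimethylamino in place of benzylamino on an aromatic carbon. Within the data shown here, the only measured step that touches this position is a 1.2-fold higher number from compound 1 to compound 2 (0.06 log units; within the scatter), which shows that replacing chloro with benzylamino left the number where it was, within the scatter. Among the measured compounds shown here, no measured compound carries dimethylamino at this position, so nothing direct is known about that group here; the one step available points to the position tolerating exchange without a shift beyond the scatter.

The expectation for compound 3 is therefore no step beyond the scatter, a 1.0-fold lower number from compound 2 to compound 3 (0.02 log units; within the scatter). In this assay compound 3 is estimated at 650 nM, with a range from 220 nM to 1900 nM.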

Compound 3, inhibition constant: 122 nM
Compound 3: the middle estimate sits 5.3-fold (0.73 log units) above what was measured, and the stated range ends above it.
By their numbers in this assay, from the lowest: compound 3; then compounds 1 and 2 (each within the scatter of the next).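

The position is not as indifferent to exchange as the chloro and benzylamino pair suggested: in this assay, dimethylamino in place of benzylamino gives a 5.5-fold lower number from compound 2 to compound 3 (0.74 log units; beyond the scatter), and dimethylamino in place of chloro gives a 4.8-fold lower number from compound 1 to compound 3 (0.68 log units; beyond the scatter). Both steps lie beyond the scatter and both end at compound 3, so the group on this aromatic carbon can change the number, and of the three groups shown, only dimethylamino separates from the others. Dimethylamino differs from benzylamino in having no ring and 0 hydrogen-bond donors, but the data shown do not tell which of these differences goes with the lower number, and no supporting measurement bears on the result.

As far as these compounds go, whether the lower number is particular to dimethylamino or extends to other amines, such as methylamino, diethylamino or pyrrolidine, remains open. Also open, from the compounds shown here alone, is whether the step holds when the benzyl group on the amide is replaced, for example by a cyclohexyl group, since all three compounds share that amide.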